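This account rests on a few compounds, and the source may have more. Where it says the series, first, only, none or still open, it means among the compounds named here.

In a functional assay on A2780 cells (Homo sapiens) for antiproliferative activity, read by resazurin assay, with a stated time of 72 h (a lower number here means a stronger inhibitor, a higher number a weaker inhibitor), three amides on a shared core have been measured. Compound 1 `CCCN(C)C(=O)c1cc2c(Cc3ccccc3)n[nH]c2cc1O` gives only a limit of the assay, > 10000 nM. Compound 2 `CN(Cc1ccccc1F)C(=O)c1cc2c(Cc3ccccc3)n[nH]c2cc1O` gives 1500 nM. Compound 3 `Cc1ccccc1CN(C)C(=O)c1cc2c(Cc3ccccc3)n[nH]c2cc1O` gives 4400 nM, the higher of the two actual numbers, and compound 2 is its nearest neighbour.

Compound 4 `CN(Cc1cccc(F)c1)C(=O)c1cc2c(Cc3ccccc3)n[nH]c2cc1O` differs from compound 3 as follows: 3-fluorophenyl in place of 2-methylphenyl on a saturated chain carbon bound to an amide-type nitrogen. In words, 3-fluorophenyl stands in place of 2-methylphenyl on a saturated chain carbon bound to an amide-type nitrogen.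

Among the compounds with values here, three measured steps bear on this change. Placing an aromatic group in place of ethyl gave an at least 6.6-fold lower number from compound 1 to compound 2 (0.82 log units; beyond the scatter) with 2-fluorophenyl and an at least 2.2-fold lower number from compound 1 to compound 3 (0.35 log units; beyond the scatter) with 2-methylphenyl, so an aromatic group of this kind is expected to be tolerated in compound 4. The closest guide is a 2.9-fold higher number from compound 2 to compound 3 (0.47 log units; beyond the scatter), where methyl took the place of fluoro on an aromatic carbon. Within the data shown here, that step favours the fluorinated ring, but no measured compound carries 3-fluorophenyl, so only part of it is expected to carry over.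

A small move toward a lower number is therefore expected in this assay, and the estimated step is a 1.8-fold lower number from compound 3 to compound 4 (0.26 log units; within the scatter). Compound 4 is estimated at about 2400 nM, with an expected range of 800 nM to 7000 nM.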

Compound 4, half-maximal inhibitory concentration: 5000 nM
For compound 4 the middle estimate is 2.1-fold (0.32 log units) below the measured one, and the stated range covers the measured number.
By their numbers in this assay, from the lowest: compound 2; then compounds 3 and 4 (each within the scatter of the next). At a limit, above all of these: compound 1.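

In this assay, the change gives a 1.1-fold higher number from compound 3 to compound 4 (0.06 log units; within the scatter), so the 3-fluorophenyl and 2-methylphenyl groups cannot be told apart at this saturated chain carbon bound to an amide-type nitrogen. The new compound also shows that a fluorine on the ring does not by itself secure the lower number seen for compound 2: replacing 2-fluorophenyl with 3-fluorophenyl gives a 3.3-fold higher number from compound 2 to compound 4 (0.52 log units; beyond the scatter), so among these fluorinated rings the outcome depends on which of the two is present. The comparison with the ethyl group reads an at least 2.0-fold lower number from compound 1 to compound 4 (0.30 log units; that floor lies within the scatter), a floor set by a limit of the assay, and it does not establish that 3-fluorophenyl improves on ethyl: the limit of > 10000 nM in this assay, at which 1 of the 4 values shown sits.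

The compounds shown leave open how an unsubstituted phenyl, a 4-fluorophenyl or a 3-methylphenyl group would read at this chain carbon, and therefore whether the advantage of compound 2 belongs to 2-fluorophenyl alone. They also leave open whether a 2-chlorophenyl group or a pyridine ring would match compound 2 or fall with compound 3 and compound 4.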